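Swapping the N-aryl group on a methylated core

A few compounds are considered here, and "the series" means these few. Any claim that something is new, unique, unknown or untested is made for them only; others in the source may bear on it.

Three analogues of one core have been tested in a functional assay on HepG2 cells (Homo sapiens) for cytotoxicity, read by MTT assay, with a stated time of 72 h; on this read-out lower numbers stand for stronger inhibition and higher numbers for weaker inhibition. Compound 1 `Cc1cc(=O)n(-c2ccccc2OC(F)(F)F)nc1C(=O)Nc1ccc(Oc2ncnc3[nH]ccc23)cc1` gives 22800 nM, and compound 2 `Cc1cc(=O)n(-c2ccc(Br)cc2F)nc1C(=O)Nc1ccc(Oc2ncnc3[nH]ccc23)cc1` gives 3660 nM in this assay, so the step of a 6.2-fold lower number from compound 1 to compound 2 (0.79 log units; beyond the scatter) is a clear gain. Compound 3 `Cc1cc(=O)n(-c2ccccc2OC(F)(F)F)nc1C(=O)Nc1ccc(Oc2ncnc3c2ccn3C)cc1` carries a methyl in place of hydrogen on an aromatic nitrogen of the core. For compound 3 the read-out in this assay is > 60000 nM, which is the limit of > 60000 nM in this assay, at which 1 of the 3 values shown sits, not a measured number. From the compounds shown here alone, the step of an at least 2.6-fold higher number from compound 1 to compound 3 (0.42 log units; beyond the scatter) therefore shows a loss whose full size is unknown.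

Compound 4 `Cc1cc(=O)n(-c2ccc(Br)cc2F)nc1C(=O)Nc1ccc(Oc2ncnc3c2ccn3C)cc1` differs from compound 3 by 4-bromo-2-fluorophenyl in place of 2-(trifluoromethoxy)phenyl on an aromatic nitrogen. Among the compounds with values here, the only step that bears on this change is a 6.2-fold lower number from compound 1 to compound 2 (0.79 log units; beyond the scatter), measured on the unmethylated core. If a gain of similar size carries over, compound 4 should return from the limit into the measurable range of this assay, though it may still remain weak. Compound 4 is therefore expected at about 15000 nM, within a range of 5000 nM to 60000 nM. This corresponds to an expected step of an at least 4.0-fold lower number from compound 3 to compound 4 (0.60 log units; beyond the scatter).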

Compound 4, half-maximal inhibitory concentration: 33600 nM
Compound 4: the middle estimate sits 2.2-fold (0.35 log units) below what was measured; low and high end bracket the measured number.
By their numbers in this assay, from the lowest: compound 2; then compounds 1 and 4 (each within the scatter of the next). At a limit, above all of these: compound 3.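

On the methylated core, the change to 4-bromo-2-fluorophenyl in this assay gives an at least 1.7-fold lower number from compound 3 to compound 4 (0.25 log units; that floor lies within the scatter), a floor that does not by itself establish a gain, and its size cannot be set against that of the same change on the unmethylated core: the same change on two cores in this assay, a 6.2-fold lower number (0.79 log units; beyond the scatter) from compound 1 to compound 2 and an at least 1.7-fold lower number (0.25 log units; that floor lies within the scatter) from compound 3 to compound 4; the limit leaves it open whether they differ

The methyl in place of hydrogen on an aromatic nitrogen now has a step of full size, a 9.2-fold higher number from compound 2 to compound 4 (0.96 log units; beyond the scatter), and the higher number appears with 4-bromo-2-fluorophenyl as well as with 2-(trifluoromethoxy)phenyl. Whether the two steps for this methyl are of equal size remains unsettled: the same change on two cores in this assay, an at least 2.6-fold higher number (0.42 log units; beyond the scatter) from compound 1 to compound 3 and a 9.2-fold higher number (0.96 log units; beyond the scatter) from compound 2 to compound 4; the limit leaves it open whether they differ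

The compounds shown leave open how an unsubstituted phenyl or a pyridine ring would fare in place of these two aryl groups. They also leave open what an ethyl group would do in place of the methyl on the core.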